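The compounds below may be only part of what the source reports. "The series", "measured", "known", "first", "only" and "open" are said of these compounds alone.

Among the compounds with values here, in a functional assay for inhibition, with Homo sapiens as the target (a lower number here means a stronger inhibitor, a higher number a weaker inhibitor), compound 1 (`O=C(O)CCCCCCCn1nc(-c2ccccc2)c(-c2ccccc2)c1-c1ccccc1`) gives 3400 nM as the only actual number in this small set. Compound 2 (`O=C(O)CCCCCCCCn1nc(-c2ccccc2)c(Cc2ccccc2)c1-c1ccccc1`) shows > 68000 nM as a limit and not a number. Compound 3 (`O=C(O)CCCCCCCn1cc(-c2ccccc2)c(-c2ccccc2)n1`) also shows only a limit, > 85000 nM in the same test.

Compound 4 (`O=C(O)CSCCCCCCn1nc(-c2ccccc2)c(-c2ccccc2)c1-c1ccccc1`) has not been measured yet. Its difference from the earlier compound is (carboxymethyl)sulfanyl in place of carboxymethyl on a saturated chain carbon, six bonds along the chain from an aromatic nitrogen in one place: (carboxymethyl)sulfanyl in place of carboxymethyl on a saturated chain carbon, six bonds along the chain from an aromatic nitrogen.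

Within the data shown here, the one measured single change, an at least 25-fold higher number from compound 1 to compound 3 (1.39 log units; beyond the scatter), is large and beyond the scatter, but it puts hydrogen in place of phenyl on an aromatic carbon of the core. Among the measured compounds shown here, no measured step alters the chain alone, and the new change leaves the core of compound 1 untouched, so that large step does not carry over. The expected result is a 1.1-fold lower number from compound 1 to compound 4 (0.05 log units; within the scatter) in this assay, which means no clear shift in either direction. For compound 4 the estimated value is 3000 nM, with an expected range from 800 nM to 14000 nM that stays wide for lack of any direct comparison.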

Compound 4, half-maximal inhibitory concentration: 870 nM
Compound 4: the middle estimate sits 3.4-fold (0.54 log units) above what was measured; measured number inside the range.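

Within the data shown here, this is the first measured step that alters the chain alone and leaves the shared core untouched. In this assay, placing (carboxymethyl)sulfanyl where carboxymethyl stood gives a 3.9-fold lower number from compound 1 to compound 4 (0.59 log units; beyond the scatter), so this position on a saturated chain carbon, six bonds along the chain from an aromatic nitrogen, accepts a sulfur in the chain and the inhibitor comes out modestly stronger. Nothing measured here accounts for why this step occurs.

With a single chain change on record, it remains unclear whether the sulfur itself matters or whether any similar change at this position would do the same. An ether oxygen or a sulfone in the same place could separate those two readings, and a longer chain carrying the sulfur would show how far the gain extends.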